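The source may report more compounds than this note shows. Statements on the series, on what has been measured and on what is new or still open speak of the compounds shown alone.

Measured in a functional assay on M4E cells (Homo sapiens) for cytotoxicity, read by resazurin assay, with a stated time of 72 h; on this read-out higher numbers stand for weaker inhibition and lower numbers for stronger inhibition:
Compound 1 `COc1cc(/C=C/C(=O)OCCCO[N+](=O)[O-])ccc1OCCCO[N+](=O)[O-]`: > 50000 nM (a limit)
Compound 2 `COc1cc(/C=C/C(=O)OCCCO[N+](=O)[O-])ccc1O`: 18400 nM

Compound 1 gives only a limit, > 50000 nM, and no number. Compound 3 `O=C(/C=C/c1ccc(OCCCO[N+](=O)[O-])c(O)c1)OCCCO[N+](=O)[O-]` differs from it by hydrogen in place of methyl on an oxygen on an aromatic ring, methoxy to hydroxy. Within the data shown here, the one measured step bearing on this is an at least 2.7-fold lower number from compound 1 to compound 2 (0.43 log units; beyond the scatter), which put hydrogen in place of 3-(nitrooxy)propyl on an oxygen on an aromatic ring. A modest step towards a lower number is therefore expected in this assay. The expected change is an at least 2.5-fold lower number from compound 1 to compound 3 (0.39 log units; beyond the scatter). The estimate for compound 3 is 20000 nM, with an estimated range of 7000 nM to 50000 nM.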

Compound 3, half-maximal inhibitory concentration: 14100 nM
For compound 3 the middle estimate is 1.4-fold (0.15 log units) above the measured one; the range from low to high includes it.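

The earlier step changed only the oxygen carrying 3-(nitrooxy)propyl. Here, hydrogen in place of methyl on the other oxygen on the aromatic ring, methoxy to hydroxy, gives an at least 3.5-fold lower number from compound 1 to compound 3 (0.54 log units; beyond the scatter) in this assay and so shows that this position also affects the read-out. Compound 1 gives only a limit, so this step sets a minimum and not a size: the limit of > 50000 nM in this assay, at which 1 of the 3 values shown sits.

As far as these compounds go, what remains open is whether an ethyl group or a longer chain on this oxygen would keep the number near that of the hydroxy or of the methoxy. An amine in place of the hydroxy is also left open.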